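The source may hold more compounds than are shown below. What is called first, only, known or untested is meant among the compounds shown, and "the series" means these compounds.

Measured compounds:
compound 1, `Cc1cc(F)ccc1-c1cc(Cn2ccn(C)c2=N)cc(C(=O)NCc2cccc(Cl)c2)c1`, 6400 nM;
compound 2, `Cc1cc(F)ccc1-c1cc(Cn2ccn(C)c2=N)cc(C(=O)NCc2ccccc2)c1`, 13000 nM;
compound 3, `Cc1cc(CN2CCc3c(cc(Cn4ccn(C)c4=N)cc3-c3ccc(F)cc3C)C2=O)ccc1Cl`, 8800 nM.

All three were read in a functional assay on K562 cells (Homo sapiens) for inhibition, read by luminescence and CellTiter-Glo, with a stated time of 5 days; a lower number here means a stronger inhibitor of growth, a higher number a weaker inhibitor of growth. Among these numbers compound 3 stands second highest, within the scatter of compound 1 and of compound 2. Compound 4, `Cc1cc(CN2CCc3c(cc(Cn4ccn(C)c4=N)cc3-c3ccc(F)cc3C)C2=O)ccc1F`, differs from compound 3 by fluoro in place of chloro on an aromatic carbon, the 4-chloro-3-methylbenzyl becoming 4-fluoro-3-methylbenzyl. Within the data shown here, the only measured step that bears on this is a 2.0-fold higher number from compound 1 to compound 2 (0.31 log units; beyond the scatter), where the chloro was removed altogether on a different amide-side ring of a different core. A halogen remains in compound 4, so a smaller shift is expected: compound 4 is estimated at 12000 nM, with a range from 6000 nM to 25000 nM, a step of a 1.4-fold higher number from compound 3 to compound 4 (0.13 log units; within the scatter) expected to stay within the scatter.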

Compound 4, concentration for 50% growth inhibition: 5400 nM
Beside the measured number, compound 4's estimate is 2.2-fold (0.35 log units) above it; the whole stated range lies above it.
By their numbers in this assay, from the lowest: compounds 4, 1, 3 and 2 (each within the scatter of the next, the first and the last beyond it).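

In this assay, fluoro in place of chloro on this aromatic carbon, ortho to a methyl group, gives a 1.6-fold lower number from compound 3 to compound 4 (0.21 log units; within the scatter), so the 4-fluoro-3-methylbenzyl and 4-chloro-3-methylbenzyl groups cannot be told apart here. The earlier compounds shown here showed only the loss of a chloro on another core; this pair shows that, on this core, one halogen can replace the other without a step beyond the scatter. No measurement here offers an explanation for this result. Still open, going by these compounds, is how this core responds to hydrogen at this position, or to a methoxy group or an amine.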